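The source may report more compounds than this note shows. Statements on the series, on what has been measured and on what is new or still open speak of the compounds shown alone.

Going by the values given here, compound 1 `O=C1c2c[n+]([O-])c3ccccc3c2C(=O)c2c1c1ccccc1n2CCCCn1ccnc1` is the only compound with a number in a functional assay on MCF7 cells (Homo sapiens) for cytotoxicity, read by MTT assay, with a stated time of 72 h; a higher number here means a weaker inhibitor, a lower number a stronger inhibitor: compound 1 gives 130 nM. Compound 2 `O=C1c2c[n+]([O-])c3ccccc3c2C(=O)c2c1c1ccccc1n2Cc1cn(C[C@H](O)CO)nn1` gives only a limit in this assay, > 1000 nM. Among the compounds with values here, the one measured step, an at least 7.6-fold higher number from compound 1 to compound 2 (0.88 log units; beyond the scatter), is therefore known only as a floor, resting on (the limit of > 1000 nM in this assay, at which 1 of the 2 values shown sits). Compound 3 `CN(C)CCCCn1c2c(c3ccccc31)C(=O)c1c[n+]([O-])c3ccccc3c1C2=O` differs from compound 1 by dimethylamino in place of 1H-imidazol-1-yl on a saturated chain carbon, four bonds along the chain from an aromatic nitrogen. That measured step changed a different part of the chain, so it bears only loosely here, and no step beyond the scatter is expected. Compound 3 is estimated at 150 nM, between 50 nM and 500 nM. The expected step is a 1.2-fold higher number from compound 1 to compound 3 (0.06 log units; within the scatter).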

Compound 3, half-maximal inhibitory concentration: 220 nM
Compound 3: the middle estimate sits 1.5-fold (0.17 log units) below what was measured; the range from low to high includes it.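

In this assay the change from 1H-imidazol-1-yl to dimethylamino on a saturated chain carbon, four bonds along the chain from an aromatic nitrogen, gives a 1.7-fold higher number from compound 1 to compound 3 (0.23 log units; within the scatter) and so stays within the scatter: at this place, the imidazole ring can be replaced by a group with no ring without a measurable change. The other new step, an at least 4.5-fold lower number from compound 2 to compound 3 (0.65 log units; beyond the scatter) is only a floor, set by a limit: the limit of > 1000 nM in this assay, at which 1 of the 3 values shown sits. The compounds shown leave open whether a primary amine or a carboxylic acid at this place would hold the same level, and whether a shorter or longer chain would do so.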